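Replacing the Ring-Nitrogen Group: What Compound 3 May Show

The source may report more compounds than this note shows. Statements on the series, on what has been measured and on what is new or still open speak of the compounds shown alone.

In a functional assay on CHO-K1 cells with Glucose-dependent insulinotropic receptor (Homo sapiens) as the target, read by a luciferase reporter, with a stated time of 5 h (on this read-out lower numbers stand for smaller maximal responses and higher numbers for larger maximal responses), compound 1 `COC(=O)N1CCC(Oc2ncnc3c2CCN3c2ccc(S(C)(=O)=O)cc2F)CC1` gives 119%.
In this assay compound 2 `CS(=O)(=O)c1ccc(N2CCc3c(OC4CCN(C(=S)Sc5ccccc5)CC4)ncnc32)c(F)c1` gives 103%.

Compound 2 stands lowest of the two numbers, with compound 1 above it by a number 16 percentage points lower from compound 1 to compound 2 (beyond the scatter). Compound 3 `CS(=O)(=O)c1ccc(N2CCc3c(OC4CCN(C5=NCCCN5)CC4)ncnc32)c(F)c1` differs from compound 2 by a group of 6 heavy atoms (4 carbon, 2 nitrogen; one six-membered non-aromatic ring with 2 hetero atoms) in place of a group of 9 heavy atoms (7 carbon, 2 sulfur; one six-membered aromatic ring of carbon only), on an amine nitrogen in a ring. Going by the values given here, no measured step concerns this change; the only step on record involves a different group at the same nitrogen, so it offers little guidance. The step from compound 2 to compound 3 is therefore expected to stay within the scatter, a number 5 percentage points higher from compound 2 to compound 3 (within the scatter). Compound 3 is estimated at 108%, in the range 90% to 126%.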

Compound 3, largest response reached (reported as percent of maximum), in percent of the reference or control that the assay uses: 66%
Estimate against measurement, compound 3: 42 percentage points above; the whole stated range lies above it.
By their numbers in this assay, from the lowest: compound 3; then compound 2; then compound 1.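

In this assay the group on the amine nitrogen proves able to change the maximal response far more than the first pair showed: replacing the sulfur-containing group with the six-membered non-aromatic ring gives a number 37 percentage points lower from compound 2 to compound 3 (beyond the scatter), and replacing the carbon-and-oxygen group with that ring gives a number 53 percentage points lower from compound 1 to compound 3 (beyond the scatter). Both steps exceed a number 16 percentage points lower from compound 1 to compound 2 (beyond the scatter). No measurement available here explains the drop.

On these data alone, whether the ring itself or its hydrogen-bond donor matters remains open. A urea or an open-chain amidine on this nitrogen could help separate the two.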